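The source may report more compounds than this note shows. Statements on the series, on what has been measured and on what is new or still open speak of the compounds shown alone.

Working notes on the series, cytotoxicity arm.

Three compounds have numbers in an ADME assay on MT4 cells (Homo sapiens) for cytotoxicity, read by MTT assay; a lower number here means that less compound is tolerated, a higher number that more compound is tolerated. Compound 1 `Cc1ccc(-c2c(C)nc(NS(=O)(=O)c3cccc4ccccc34)c(C)c2C(OC(C)(C)C)C(=O)O)cc1C` gives 16000 nM in this assay. Compound 2 `Cc1nc(NC(=O)NC2CCCCC2)c(C)c(C(OC(C)(C)C)C(=O)O)c1-c1ccc2c(c1C)CCCO2` gives 11000 nM in this assay. Compound 3 `Cc1ccc(-c2c(C)nc(Nc3nc4ccccc4s3)c(C)c2C(OC(C)(C)C)C(=O)O)cc1C` gives 6600 nM in this assay, the smallest of the three numbers; compound 2 sits within the scatter of it, while compound 1 lies beyond the scatter, at a higher number. Among the compounds with values here, no two of the measured compounds differ in a single place, so no isolated step is available from them.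

Compound 4 `Cc1ccc(-c2c(C)nc(C(=O)N(C)Cc3ccccc3)c(C)c2C(OC(C)(C)C)C(=O)O)cc1C` is not yet measured. Against compound 3 the change is benzyl(methyl)carbamoyl in place of (1,3-benzothiazol-2-yl)amino on an aromatic carbon. Within the data shown here, nothing among the measured compounds repeats this change, so its effect in this assay is unknown; the three measured numbers span a narrow band, and the expectation is a step of a 1.8-fold higher number from compound 3 to compound 4 (0.26 log units; within the scatter) of modest size, if any, in the direction of a higher number. For compound 4 the estimated value in this assay is 12000 nM, expected to fall between 5000 nM and 30000 nM.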

Compound 4, half-maximal cytotoxic concentration: 77000 nM
For compound 4 the middle estimate is 6.4-fold (0.81 log units) below the measured one, and the stated range ends below it.
By their numbers in this assay, from the lowest: compounds 3, 2 and 1 (each within the scatter of the next, the first and the last beyond it); then compound 4.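

At the aromatic carbon next to the ring nitrogen, benzyl(methyl)carbamoyl in place of (1,3-benzothiazol-2-yl)amino gives a 12-fold higher number from compound 3 to compound 4 (1.07 log units; beyond the scatter) in this assay, a large step well beyond the scatter. Within the data shown here, the earlier compounds offered no single-place step, so this is the first sign that the group at this position alone can strongly shift the number on this core. Nothing available bears on why the step is so large.

Going by these compounds, the whole group changes at once, so it remains open which part carries the step: the amino link with its hydrogen-bond donor, the carbonyl, or the rings. On these data alone, it also remains open whether a smaller group at this place, such as methylcarbamoyl, a primary amine or a carboxylic acid, would give a similarly high number.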